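Removing the Core Methyl: From Compound 3 to Compound 4

This account rests on a few compounds, and the source may have more. Where it says the series, first, only, none or still open, it means among the compounds named here.

Compound 1 `CCOC(=O)N1CCC(Oc2ncnc(Oc3ccc(/C=C4\SC(=O)NC4=O)cc3)c2C)CC1` gives 141% in a functional assay on CHO-K1 cells for agonist activity at Glucose-dependent insulinotropic receptor (Homo sapiens), read by cAMP accumulation and immunoassay, with a stated time of 1 h; on this read-out higher numbers stand for larger maximal responses and lower numbers for smaller maximal responses. Compound 2 `Cc1c(Oc2ccc(/C=C3\SC(=O)NC3=O)cc2)ncnc1OC1CCN(C(=O)OCc2ccccc2)CC1` gives 43.3%. Compound 3 `Cc1c(Oc2cccc(/C=C3\SC(=O)NC3=O)c2)ncnc1OC1CCN(C(=O)OCc2ccccc2)CC1` gives 138%.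

In this assay compound 3 stands second highest of the three numbers; compound 1 sits within the usual scatter of it, while compound 2 lies far below it. Compound 4 `O=C1NC(=O)/C(=C/c2cccc(Oc3cc(OC4CCN(C(=O)OCc5ccccc5)CC4)ncn3)c2)S1` differs from compound 3 by hydrogen in place of methyl on an aromatic carbon. Going by the values given here, the single measured step, a number 97.7 percentage points lower from compound 1 to compound 2 (beyond the scatter), concerns a phenyl in place of methyl on a saturated chain carbon bound to an oxygen next to a carbonyl group, a different place, so it gives no direct guide here. With nothing measured for this kind of change, a step within the usual scatter is expected: a number 8 percentage points lower from compound 3 to compound 4 (within the scatter). Compound 4 is therefore estimated at 130%, with a range from 85% to 160%, because compound 3 gives 138%.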

Compound 4, largest response reached (Emax), in percent of the reference or control that the assay uses: 98.3%
The estimate for compound 4 lay 31.7 percentage points above the measured number; low and high end bracket the measured number.
By their numbers in this assay, from the lowest: compound 2; then compound 4; then compounds 3 and 1 (each within the scatter of the next).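

Replacing the methyl with hydrogen on this aromatic carbon, two atoms from the ring nitrogen, is not a neutral swap: in this assay it gives a number 39.7 percentage points lower from compound 3 to compound 4 (beyond the scatter) and so costs a large part of the maximal response. Thus the loss of one carbon here is enough to change the read-out well beyond the scatter. No measurement shown explains why the response falls.

On these data alone, whether an ethyl group or a chlorine atom on this carbon would keep, raise or lower the response remains open. So does whether removing the methyl would have a similar effect in compound 1.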